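The compounds below may be only part of what the source reports. "The series", "measured", "known", "first", "only" and "open" are said of these compounds alone.

Three compounds have so far been measured in a functional assay on MCF7 cells (Homo sapiens) for antiproliferative activity, read by sulforhodamine B assay, with a stated time of 48 h; a higher number here means a weaker inhibitor, a lower number a stronger inhibitor:

Compound 1 `COc1cccc(C(=O)C2OC2c2ccc(F)cc2)c1`: 14 nM
Compound 2 `COc1cc(C2=CC(c3ccc(Cl)cc3)NC(=S)N2)cc(OC)c1OC`: 120 nM
Compound 3 `COc1ccc(C(=O)C2OC2c2ccc(Cl)cc2)cc1`: 26 nM

Of these three numbers, compound 3 holds the second highest. Its nearest neighbour is compound 1, whose value of 14 nM lies within the usual scatter of repeated measurements, so the two cannot be told apart on potency. Its furthest neighbour is compound 2, whose value of 120 nM lies beyond that scatter, so compound 2 is clearly the weaker of that pair. Compounds 1 and 3 share a core built around an epoxide bridging a carbonyl and a halogen-bearing ring; compound 2 is built differently.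

The compound still to be measured is compound 4 `COc1ccc(C(=O)C2OC2c2ccc(Br)cc2)cc1`. Set beside compound 3 it differs in one place: bromo in place of chloro on an aromatic carbon. Among the measured compounds shown here, nothing among the measured compounds shows what such an exchange does in this assay; no pair of them differs by this change alone. Halogens of neighbouring size at the same position usually leave potency much where it was, so the step from compound 3 to compound 4 is expected to stay within the scatter, as a 1.1-fold lower number from compound 3 to compound 4 (0.03 log units; within the scatter). Compound 4 is therefore estimated at 24 nM, with a likely range from 10 nM to 55 nM.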

Compound 4, half-maximal inhibitory concentration: 13 nM
Compound 4: the middle estimate sits 1.8-fold (0.27 log units) above what was measured; measured number inside the range.
By their numbers in this assay, from the lowest: compounds 4, 1 and 3 (each within the scatter of the next); then compound 2.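

In this assay, putting bromo in place of chloro on an aromatic carbon, para to a large group, gives a 2.0-fold lower number from compound 3 to compound 4 (0.30 log units; within the scatter). Among the compounds shown here, this is the first pair here that differs in one place only, so it gives the first direct reading of this position: a larger halogen atom replaces a smaller one, and the two numbers cannot be told apart, since repeated measurements of one compound could differ as much. Nothing measured here speaks to what lies behind this result, and a step this small leaves little to explain in any case.

Going by these compounds, one exchange between two halogens says little about how much freedom this position allows, and what an amine, a hydroxyl or a carboxylic acid would do on the same carbon stays open. Also open, on these data alone, is whether the methoxy group on the other aromatic ring can be changed as freely, for example by putting a longer chain such as butoxy in its place.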